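The compounds below may be only part of what the source reports. "The series", "measured", "known", "first", "only" and "open" are said of these compounds alone.

Measured compounds:
- compound 1, `COc1ccc(Oc2ccc([C@H]3S[C@@H](C)C(=O)Nc4c3c(C)nn4-c3ccccc3C)cc2)cc1`: 2200 nM
- compound 2, `CCOc1cccc(-c2ccc([C@H]3S[C@@H](C)C(=O)Nc4c3c(C)nn4-c3ccccc3C)cc2)c1`: 3500 nM

In an assay on isolated protein for agonist activity at Bile acid receptor (Homo sapiens), read by AlphaScreen, with a stated time of 30 min (on this read-out lower numbers stand for an effect already at smaller amounts and higher numbers for an effect only at larger amounts of compound), compound 1 gives 2200 nM, and compound 2 gives 3500 nM. Within the data shown here, the one step connecting them, a 1.6-fold higher number from compound 1 to compound 2 (0.20 log units; within the scatter), lies within the scatter, so compound 2 stands level with compound 1, the only other measured compound. Compound 3, `Cc1ccccc1-n1nc(C)c2c1NC(=O)[C@H](C)S[C@@H]2c1ccc(Oc2ccc(C(=O)O)cc2)cc1`, has not yet been measured in this assay. It differs from compound 2 in one place: 4-carboxyphenoxy in place of 3-ethoxyphenyl on an aromatic carbon. Among the measured compounds shown here, the single measured step concerns a different exchange on the same aromatic carbon and was within the scatter, so it gives no direct guide to a carboxyphenoxy group; no step of that kind exists among the measured compounds. With only a flat step to lean on, compound 3 is expected to give 1500 nM, between 300 nM and 6000 nM, which would be a step of a 2.3-fold lower number from compound 2 to compound 3 (0.37 log units; beyond the scatter).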

Compound 3, half-maximal effective concentration: "not active" (no number reported)
Compound 3: no number reported, and the estimate cannot be compared.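

Compound 3 was reported as "not active" in this assay, with no number, so no new step can be read between compound 2 and compound 3. No measured finding here bears on this result. The compounds shown leave open how the 4-carboxyphenoxy group compares numerically with the 3-ethoxyphenyl group.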